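Cytotoxicity When the Chloro Group Is Removed

The compounds below may be only part of what the source reports. "The series", "measured", "known", "first", "only" and "open" are said of these compounds alone.

Measured compounds:
compound 1 `Cc1cc(C)c(Oc2cc(Nc3ccc(C#N)cc3)[nH]c(=O)c2)c(C)c1`: in an ADME assay on MT4 cells (Homo sapiens) for cytotoxicity, read by MTT assay, with a stated time of 5 days (on this read-out higher numbers stand for lower toxicity in this test and lower numbers for higher toxicity in this test), compound 1 gives 32000 nM.
compound 2 `Cc1cc(C)cc(Oc2cc(Nc3ccc(C#N)cc3)[nH]c(=O)c2Cl)c1`: compound 2 gives 21000 nM.
compound 3 `Cc1cc(C)c(Oc2cc(Nc3ccc(C#N)cc3)[nH]c(=O)c2Cl)c(C)c1`: compound 3 gives > 329000 nM, which is a limit of this assay and not a number.

The three share a core and differ in two places. Between compound 3 and compound 1 the change is hydrogen in place of chloro on an aromatic carbon, and it gave an at least 10-fold lower number from compound 3 to compound 1 (1.01 log units; beyond the scatter). Between compound 3 and compound 2 the change is 3,5-dimethylphenyl in place of 2,4,6-trimethylphenyl on an oxygen on an aromatic ring, and in the reverse direction it gave an at least 15-fold higher number from compound 2 to compound 3 (1.19 log units; beyond the scatter). Both steps rest on (the limit of > 329000 nM in this assay, at which 1 of the 3 values shown sits).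

Compound 4 `Cc1cc(C)cc(Oc2cc(Nc3ccc(C#N)cc3)[nH]c(=O)c2)c1` has not been measured in this assay. It is reached from compound 2 by hydrogen in place of chloro on an aromatic carbon. Among the measured compounds shown here, this is the same kind of change as the one from compound 3 to compound 1; around the place, one description reads ortho to a large group and para to a (4-cyanophenyl)amino group, the other ortho to a group of 9 heavy atoms and para to a group of 9 heavy atoms. For the measured compounds named here, the earlier step stands beside an at least 10-fold lower number from compound 3 to compound 1 (1.01 log units; beyond the scatter); for compound 2 to compound 4 a smaller step is expected, a 1.8-fold lower number from compound 2 to compound 4 (0.24 log units; within the scatter), since compound 2 already gives 21000 nM and only one such step exists to rest on. Compound 4 is therefore estimated at 12000 nM, expected between 4000 nM and 40000 nM.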

Compound 4, half-maximal cytotoxic concentration: 46000 nM
The estimate for compound 4 lay 3.8-fold (0.58 log units) below the measured number; measured number above the stated range.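

In this assay, hydrogen in place of chloro on the core carrying the 3,5-dimethylphenyl group gave a 2.2-fold higher number from compound 2 to compound 4 (0.34 log units; beyond the scatter), which runs in the opposite direction to the earlier step, so the same change did not carry over from one core to the other: the same change on two cores in this assay, an at least 10-fold lower number (1.01 log units; beyond the scatter) from compound 3 to compound 1 and a 2.2-fold higher number (0.34 log units; beyond the scatter) from compound 2 to compound 4, at least 22-fold (1.35 log units) apart, beyond the scatter of two such steps. The comparison has one weak point, and that is compound 3, the starting point of the earlier step, which gives > 329000 nM, a limit of the assay and not a number: the limit of > 329000 nM in this assay, at which 1 of the 4 values shown sits. These two pairs show that, in this series, the effect of removing the chloro group cannot simply be copied from one core to another, but they give no reason for the reversal and no rule for any further core.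

The compounds shown leave open what other groups would do in the place of the chloro group, for example a bromo group, a methyl group or an amine. They also leave open how the change would behave with other groups on the oxygen, such as a plain phenyl or a phenyl carrying a single methyl group, and so which core the usual outcome resembles.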